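The source may report more compounds than this note shows. Statements on the series, on what has been measured and on what is new or still open speak of the compounds shown alone.

Compound 1 `COC1=C(C)C(=O)/C(=C(O)/C=C/c2ccc(OC)cc2)C(=O)C1(C)C` holds the second highest of the three numbers in a functional assay on A549 cells (Homo sapiens) for cytotoxicity (a higher number here means that more compound is needed for the effect, a lower number that less compound is needed), where compound 1 gives 3 ug/mL. Compound 2 `COC1=C(C)C(=O)/C(=C(O)/C=C/c2cccc(OC)c2)C(=O)C1(C)C` gives 2.8 ug/mL, and the step of a 1.1-fold lower number from compound 1 to compound 2 (0.03 log units; within the scatter) is within the scatter, so the two are not separated. Compound 3 `COC1=C(C)C(=O)/C(=C(O)/C=C/c2c(C)cccc2C)C(=O)C1(C)C` gives 8.3 ug/mL; the step of a 2.8-fold higher number from compound 1 to compound 3 (0.44 log units; beyond the scatter) is beyond the scatter, as is a 3.0-fold higher number from compound 2 to compound 3 (0.47 log units; beyond the scatter).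

Compound 4 `COC1=C(C)C(=O)/C(=C(O)/C=C/c2cc(C)cc(C)c2)C(=O)C1(C)C` differs from compound 1 by one exchange: 3,5-dimethylphenyl in place of 4-methoxyphenyl on a double-bonded chain carbon bound to a double-bonded chain carbon. Going by the values given here, the steps that bear on it are the two leading to compound 3, a 2.8-fold higher number from compound 1 to compound 3 (0.44 log units; beyond the scatter) and a 3.0-fold higher number from compound 2 to compound 3 (0.47 log units; beyond the scatter), both of which put a dimethylphenyl in place of a methoxyphenyl and both give a modest higher number. The step of a 1.1-fold lower number from compound 1 to compound 2 (0.03 log units; within the scatter) shows that exchanging 3-methoxyphenyl for 4-methoxyphenyl changes nothing beyond the scatter. The entering group in compound 4 is 3,5-dimethylphenyl rather than the 2,6-dimethylphenyl of compound 3, so the analogy is indirect and the size of the step is uncertain. A modest higher number is nevertheless expected in this assay, similar to or smaller than that seen for compound 3. For compound 4 the expected step is a 1.8-fold higher number from compound 1 to compound 4 (0.26 log units; within the scatter). The estimate for compound 4 is 5.5 ug/mL, with a range from 2.5 ug/mL to 12 ug/mL.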

Compound 4, concentration for half-maximal effect: 4.3 ug/mL
Estimate against measurement, compound 4: 1.3-fold (0.11 log units) above, and the stated range covers the measured number.
By their numbers in this assay, from the lowest: compounds 2, 1, 4 and 3 (each within the scatter of the next, the first and the last beyond it).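

In this assay the exchange to 3,5-dimethylphenyl on a double-bonded chain carbon bound to a double-bonded chain carbon gives a 1.4-fold higher number from compound 1 to compound 4 (0.16 log units; within the scatter) and a 1.5-fold higher number from compound 2 to compound 4 (0.19 log units; within the scatter) so a methoxyphenyl with its one hydrogen-bond acceptor can give way to an all-carbon dimethylphenyl with no hydrogen-bond acceptor without a separable change in this pair of comparisons. A dimethylphenyl in this place therefore does not in itself bring the steps beyond the scatter that compound 3 showed against compounds 1 and 2, yet a 1.9-fold lower number from compound 3 to compound 4 (0.29 log units; within the scatter) keeps compound 4 unseparated from compound 3 as well, so the 3,5-dimethylphenyl and 2,6-dimethylphenyl groups cannot be told apart on these numbers. No measurement is available that explains any of these steps.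

Every aryl group shown carries only methoxy or methyl substituents, so it remains open whether a chlorine, a dimethylamino group or a carboxylic acid on the phenyl ring would move the number beyond the scatter. Also open, on these data alone, is whether a pyridine ring in place of the phenyl ring would be tolerated at this place in the same way, and the shared core stays constant throughout, so nothing here speaks to changes elsewhere.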